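The source may hold more compounds than are shown below. What is called first, only, known or untested is meant among the compounds shown, and "the series" means these compounds.

Compound 2, with structure `Nc1nc(-c2ccc(Cl)cc2)cc(-c2ccccc2O)n1`, sits on a shared core that three measured compounds carry: compound 1, with structure `COc1ccc(-c2cc(-c3ccccc3O)nc(N)n2)cc1`, and compound 3, with structure `Cc1cccc(-c2cc(-c3ccccc3O)nc(N)n2)c1`. In an ADME assay on MT4 cells (Homo sapiens) for cytotoxicity, read by MTT assay, with a stated time of 5 days (a higher number here means that more compound is tolerated, a lower number that less compound is tolerated), compound 1 gives 92200 nM. In this assay compound 3 gives 13000 nM. Compound 2 itself reaches only a limit in this assay, namely > 74700 nM. That limit is the limit of > 74700 nM in this assay, at which 1 of the 3 values shown sits, so compound 2 is not placed at a single number and stands where tolerated concentration runs at least as high as the other two.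

The step to compound 4, with structure `Nc1nc(-c2cccs2)cc(-c2ccccc2O)n1`, is thiophen-2-yl in place of 4-chlorophenyl on an aromatic carbon. Among the measured compounds shown here, two measured steps touch the same position on the core. The step that the limit leaves unreadable from compound 1 to compound 2 cannot be sized. The step of an at least 5.7-fold lower number from compound 2 to compound 3 (0.75 log units; beyond the scatter) shows that a smaller hydrocarbon substituent on this aromatic carbon can lower the tolerated concentration in this assay by a clear margin. The change to thiophen-2-yl is smaller than either measured step, so a modest downward move from compound 2 in this assay is expected, and compound 4 is expected to land near 55000 nM, between 15000 nM and 150000 nM, the expected step being an at least 1.3-fold lower number from compound 2 to compound 4 (0.13 log units; that floor lies within the scatter).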

Compound 4, half-maximal cytotoxic concentration: 5300 nM
Beside the measured number, compound 4's estimate is 10-fold (1.02 log units) above it; measured number outside the range, below it.
By their numbers in this assay, from the lowest: compound 4; then compound 3; then compound 1.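

Putting thiophen-2-yl in place of 4-chlorophenyl on this aromatic carbon, opposite the ring nitrogen, gives an at least 14-fold lower number from compound 2 to compound 4 (1.14 log units; beyond the scatter) in this assay, and the same group in place of 3-methylphenyl gives a 2.5-fold lower number from compound 3 to compound 4 (0.39 log units; beyond the scatter). The earlier compounds all carried a substituted phenyl group at this position, so these steps are the first to show what a five-membered aromatic ring with 1 hetero atom does here, and compound 4 now holds the lowest number of those shown, beneath both phenyl-bearing compounds with a readable number. Compound 2 reaches only a limit, so the first of these steps is a floor and not a size: the limit of > 74700 nM in this assay, at which 1 of the 4 values shown sits.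

The step from compound 1 to compound 2 still cannot be read, and since ring size and the sulfur atom change together in compound 4, the compounds shown do not separate the two. Also open, on these data alone, is how the number would move with an unsubstituted phenyl, a furan-2-yl or a thiophen-3-yl group at this carbon, or with an amine or a carboxylic acid on the phenyl ring there.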